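Ethyl to allyl on an aromatic nitrogen

The source may hold more compounds than are shown below. What is called first, only, known or untested is meant among the compounds shown, and "the series" means these compounds.

In a functional assay on MCF7 cells (Homo sapiens) for cytotoxicity, read by sulforhodamine B assay, with a stated time of 48 h (a lower number here means a stronger inhibitor, a higher number a weaker inhibitor), compound 1 `N#Cc1c(-c2ccc(Cl)cc2)cc(-c2ccc(Cl)cc2)[nH]c1=O` is reported as "not active" (no number reported), without a number. Compound 2 `N#Cc1c(-c2ccc(Cl)cc2)cc(-c2ccc(Cl)cc2)n([C@@H]2O[C@H](CO)[C@@H](O)[C@H](O)[C@H]2O)c1=O` gives 14.2 ug/mL, and compound 3 `CCn1c(-c2ccc(Cl)cc2)cc(-c2ccc(Cl)cc2)c(C#N)c1=O` gives 19.7 ug/mL, which places compound 3 level with compound 2. Compound 4 `C=CCn1c(-c2ccc(Cl)cc2)cc(-c2ccc(Cl)cc2)c(C#N)c1=O` has vinyl in place of methyl on a saturated chain carbon bound to an aromatic nitrogen, so ethyl becomes allyl: vinyl in place of methyl on a saturated chain carbon bound to an aromatic nitrogen. Among the compounds with values here, the only measured step at that nitrogen exchanges 3,4,5-trihydroxy-6-(hydroxymethyl)oxan-2-yl for ethyl, and it is small: a 1.4-fold higher number from compound 2 to compound 3 (0.14 log units; within the scatter). No shift beyond the scatter is therefore expected. For compound 4 the estimate is 18 ug/mL, with an expected range of 8 ug/mL to 40 ug/mL. This estimate means an expected 1.1-fold lower number from compound 3 to compound 4 (0.04 log units; within the scatter).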

Compound 4, half-maximal inhibitory concentration: 19 ug/mL
Compound 4: the middle estimate sits 1.1-fold (0.02 log units) below what was measured, within the range that was stated.
By their numbers in this assay, from the lowest: compounds 2, 4 and 3 (each within the scatter of the next).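

In this assay, vinyl in place of methyl on a saturated chain carbon bound to an aromatic nitrogen gives a 1.0-fold lower number from compound 3 to compound 4 (0.02 log units; within the scatter) and so separates nothing between these two small chains. Allyl in place of 3,4,5-trihydroxy-6-(hydroxymethyl)oxan-2-yl on that nitrogen gives a 1.3-fold higher number from compound 2 to compound 4 (0.13 log units; within the scatter) and so puts compound 2, compound 3 and compound 4 level despite their very different groups there. The data shown offer no evidence on why these values sit level. From the compounds shown here alone, whether a longer chain, a benzyl group, an amine or a carboxylic acid on that nitrogen would stay level remains open.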